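The source may hold more compounds than are shown below. What is called first, only, known or untested is meant among the compounds shown, and "the series" means these compounds.

Measured compounds:
- compound 1, `COc1ccc(-c2c(C)[nH]c(=O)n2C)cc1`: in a functional assay on brain (Rattus norvegicus, strain Wistar) for inhibition (on this read-out lower numbers stand for stronger inhibition and higher numbers for weaker inhibition), compound 1 gives 147000 nM.
- compound 2, `CCCCCCCCCCCCCCCCCCc1ccc(-c2c(C)[nH]c(=O)n2C)cc1`: for compound 2 this assay reports only a limit, > 100000 nM.

Among the compounds with values here, compound 1 is the only compound of the pair with a number in this assay, and that number stands far up the range, so inhibition is weak. The other value is a limit, (the limit of > 100000 nM in this assay, at which 1 of the 2 values shown sits), which sets no number against compound 1 and allows no ordering of the two. Within the data shown here, no step between measured compounds is available, so the scale of this series under change is unknown.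

Compound 3, `Cc1[nH]c(=O)n(C)c1-c1ccc(Oc2ccccc2)cc1`, is not yet measured. It differs from compound 1 in one place: phenyl in place of methyl on an oxygen on an aromatic ring. Among the measured compounds shown here, the change stays at the oxygen on the aromatic ring of the shared core, and the data offer no measured step that would set a direction for it.

Given only the weak number of compound 1 and the limit for compound 2, a step of a 1.3-fold lower number from compound 1 to compound 3 (0.13 log units; within the scatter) is expected, within or near the scatter, and the estimate for compound 3 in this assay is 110000 nM, with a range from 35000 nM to 350000 nM, and a fair chance that only a limit is reported.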

Compound 3, half-maximal inhibitory concentration: 8100 nM
Compound 3: the middle estimate sits 14-fold (1.13 log units) above what was measured; measured number outside the range, below it.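

Within the data shown here, at the oxygen on the aromatic ring of the shared core, the change from methoxy to phenoxy gives the first readable step in this assay: an 18-fold lower number from compound 1 to compound 3 (1.26 log units; beyond the scatter). This shows that the group on this oxygen can move the read-out well beyond the scatter, and that adding one six-membered aromatic ring of carbon at this place goes with stronger inhibition, with compound 3 at 8100 nM. Compound 2 is reported only as a limit, > 100000 nM, so it adds no second step, and nothing shown gives a cause for the change at this position.

Whether the step depends on the aromatic ring itself stays open, since the compounds shown do not separate it from other groups on the oxygen, such as cyclohexyl, benzyl or a short chain like ethyl. Also open, going by these compounds, are the role of the oxygen as the link, which a compound with an amine in its place would test, and the effect of a chlorine or a carboxylic acid on the new phenyl ring.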